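This account rests on a few compounds, and the source may have more. Where it says the series, first, only, none or still open, it means among the compounds named here.

Measured so far in a functional assay on HeLa cells (Homo sapiens) for inhibition, read by CCK-8 assay, with a stated time of 72 h; on this read-out lower numbers stand for stronger inhibition and higher numbers for weaker inhibition 
compound 1 `O=C(NO)c1ccc(CNC(=O)c2n[nH]cc2NC(=O)c2c(Cl)cccc2Cl)cc1` gives 4840 nM 
compound 2 `Nc1ccccc1NC(=O)c1ccc(CNC(=O)c2n[nH]cc2NC(=O)c2ccccc2F)cc1` gives 3440 nM 

On these numbers compound 2 at 3440 nM sits within the usual scatter of compound 1 at 4840 nM and cannot be separated from it. Compound 3 `O=C(NO)c1ccc(CNC(=O)c2n[nH]cc2NC(=O)c2ccccc2F)cc1` has not been measured. It differs from compound 2 in one place hydroxy in place of 2-aminophenyl on an amide-type nitrogen and so carries hydroxy in place of 2-aminophenyl on an amide-type nitrogen, which turns the (2-aminophenyl)carbamoyl end into a hydroxycarbamoyl end.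

Among the compounds with values here, no measured step between compounds differing in one place exists, so the size of this change has no direct precedent. Within the data shown here, the only guide is indirect. Compound 1 with 4840 nM also has the hydroxycarbamoyl end, though it differs from compound 3 elsewhere as well, and its value lies within the scatter of that of compound 2. No step beyond the scatter is therefore expected, in either direction. The estimate is a 1.1-fold lower number from compound 2 to compound 3 (0.06 log units; within the scatter) and stays within the scatter. For compound 3 the expected value is 3000 nM with an estimated range from 900 nM to 9000 nM in this read-out.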

Compound 3, half-maximal inhibitory concentration: 6610 nM
The estimate for compound 3 lay 2.2-fold (0.34 log units) below the measured number; the range from low to high includes it.
By their numbers in this assay, from the lowest: compounds 2, 1 and 3 (each within the scatter of the next).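

In this assay, hydroxy in place of 2-aminophenyl on an amide-type nitrogen, with the 2-fluorophenyl group held constant, gives a 1.9-fold higher number from compound 2 to compound 3 (0.28 log units; within the scatter). Within the data shown here, this is the first direct reading at this position: a six-membered aromatic ring of carbon only leaves and a hydroxy enters, yet the (2-aminophenyl)carbamoyl and hydroxycarbamoyl ends cannot be separated in this read-out. With the hydroxycarbamoyl end held constant, 2-fluorophenyl in place of 2,6-dichlorophenyl on a carbonyl carbon gives a 1.4-fold higher number from compound 1 to compound 3 (0.14 log units; within the scatter), so neither single change separates its pair, and no data on hand bear on the reason for this result.

Still open, on these data alone, is whether the 2-aminophenyl end would also match the hydroxycarbamoyl end with 2,6-dichlorophenyl on the carbonyl carbon, since the two changes have been read only one at a time and on different partners. Also open, as far as these compounds go, is whether any replacement at the amide-type nitrogen or the carbonyl end, such as methoxy on that nitrogen or a carboxylic acid in place of the hydroxycarbamoyl end, would produce a step beyond the scatter.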